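A new group on the sulfonyl sulfur

The compounds below may be only part of what the source reports. "The series", "measured", "known", "first", "only" and "open" are said of these compounds alone.

Measured in an ADME assay on microsomes from liver (Mus musculus, strain CD-1) for pharmacokinetics, read by LC-MS, with a stated time of 60 min, tested at 1 uM (on this read-out lower numbers stand for slow clearance and higher numbers for fast clearance), so far
Compound 1 `Nc1ccc(CNC(=O)Nc2ccc(S(=O)(=O)c3ccccc3)cc2)cn1` gives 42 mL/min/kg here
Compound 2 `C[C@@H]1CN(S(=O)(=O)c2ccc(NC(=O)NCc3cccnc3)cc2)C[C@H](C)O1` gives 81 mL/min/kg here

Within the data shown here, compound 2 (81 mL/min/kg) and compound 1 (42 mL/min/kg) lie within the scatter of each other, so compound 2 stands level with the only other number available. Compound 3 `O=C(NCc1cccnc1)Nc1ccc(S(=O)(=O)N2CCC3(CCNC3)CC2)cc1` differs from compound 2 on the sulfonyl sulfur (a group of 10 heavy atoms (8 carbon, 2 nitrogen; one five-membered non-aromatic ring with 1 hetero atom, one six-membered non-aromatic ring with 1 hetero atom) in place of a group of 8 heavy atoms (6 carbon, 1 nitrogen, 1 oxygen; one six-membered non-aromatic ring with 2 hetero atoms), on a sulfonyl sulfur). Among the measured compounds shown here, no measured pair shows a change of this kind, so the expectation rests on little. The expected step in this assay is a modest fall that stays within the scatter (a 1.6-fold lower number from compound 2 to compound 3 (0.21 log units; within the scatter)). For compound 3 the estimated clearance is 50 mL/min/kg (expected range 22 mL/min/kg to 105 mL/min/kg).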

Compound 3, clearance: 44 mL/min/kg
Estimate against measurement, compound 3: 1.1-fold (0.06 log units) above; the measured number falls inside the stated range.
By their numbers in this assay, from the lowest: compounds 1, 3 and 2 (each within the scatter of the next).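

In this assay, putting a group of 10 heavy atoms with a five-membered and a six-membered non-aromatic ring in place of 2,6-dimethylmorpholin-4-yl on the sulfonyl sulfur gives a 1.8-fold lower number from compound 2 to compound 3 (0.27 log units; within the scatter). This single step shows that the position accepts a group with 1 hydrogen-bond donor and a second ring without a move beyond the scatter. Nothing available explains this result. Still open, going by these compounds, is how an open-chain amine such as dimethylamino, or a plain piperidine, would read on the same sulfur.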